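Compound 3: from carboxy to methoxycarbonyl

A few compounds are considered here, and "the series" means these few. Any claim that something is new, unique, unknown or untested is made for them only; others in the source may bear on it.

In a functional assay on L1210 cells (Mus musculus) for inhibition (on this read-out higher numbers stand for weaker inhibition and lower numbers for stronger inhibition), compound 1 (`CN(Cc1cnc2nc(N)nc(N)c2n1)c1ccc(C(=O)NC(CCC(=O)NN)C(=O)O)cc1`) gives 0.02 uM and compound 2 (`CN(Cc1cnc2nc(N)nc(N)c2n1)c1ccc(C(=O)NC(CCC(=O)OC(C)(C)C)C(=O)O)cc1`) gives 0.02 uM as well, so compound 2 stands level with compound 1. Compound 3 (`COC(=O)C(CCC(=O)OC(C)(C)C)NC(=O)c1ccc(N(C)Cc2cnc3nc(N)nc(N)c3n2)cc1`) differs from compound 2 by methyl in place of hydrogen on an oxygen next to a carbonyl group in one place: methyl in place of hydrogen on an oxygen next to a carbonyl group, which reads carboxy to methoxycarbonyl. For the measured compounds named here, the one measured step shows no change at the digits printed from compound 1 to compound 2 (within the scatter) when tert-butoxy replaces aminoamino on a carbonyl carbon. From the compounds shown here alone, both of those compounds keep the carboxy group, so that step does not test the new change, and the size of any effect remains open. A modest shift toward weaker inhibition in this assay is the cautious expectation, an estimated 2.5-fold higher number from compound 2 to compound 3 (0.40 log units; beyond the scatter) with wide uncertainty. Compound 3 is expected at 0.05 uM within an estimated range from 0.01 uM to 0.3 uM as a working estimate.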

Compound 3, concentration for 50% inhibition: 4.9 uM
Estimate against measurement, compound 3: 98-fold (1.99 log units) below, and the stated range ends below it.
By their numbers in this assay, from the lowest: compounds 1 and 2 (each within the scatter of the next); then compound 3.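

In this assay, methyl in place of hydrogen on an oxygen next to a carbonyl group, which turns carboxy into methoxycarbonyl, gives a 250-fold higher number from compound 2 to compound 3 (2.39 log units; beyond the scatter), a large loss of inhibition. The earlier change, tert-butoxy in place of aminoamino on a carbonyl carbon, gave no change at the digits printed from compound 1 to compound 2 (within the scatter), so this read-out tolerated that swap but responds sharply to a single methyl on the carboxy group. Nothing measured here explains the size of this step.

The compounds shown leave open whether any group in place of carboxy would give a similar loss, such as a primary amide or the longer ethoxycarbonyl. Also open, from the compounds shown here alone, is whether methoxycarbonyl would give a step of similar size with the aminoamino group of compound 1 kept.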